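The compounds below may be only part of what the source reports. "The series", "measured", "known", "first", "only" and "open" are said of these compounds alone.

Compound 1 `O=C(NCCCNc1nc(Nc2ccccc2F)ncc1C1CC1)c1cccs1` carries a 2-fluorophenyl on a nitrogen on an aromatic ring of the shared core, and in an assay on isolated protein for inhibition of serine/threonine-protein kinase TBK1 (Homo sapiens) (on this read-out lower numbers stand for stronger inhibition and higher numbers for weaker inhibition), compound 1 gives 820 nM. Compound 2 `O=C(NCCCNc1nc(NCc2ccc(F)cc2)ncc1C1CC1)c1cccs1` differs from it in one place. In this assay compound 2 reaches only > 10000 nM, which is a limit of the assay and not a number. The step of an at least 12-fold higher number from compound 1 to compound 2 (1.08 log units; beyond the scatter) is thus known only as a lower bound, and compound 2 stands at the limit (the limit of > 10000 nM in this assay, at which 1 of the 3 values shown sits). Compound 3 `CN1CCN(C(=O)c2ccc(Nc3ncc(C4CC4)c(NCCCNC(=O)C4CCC4)n3)cc2)CC1`, a more distant relative, gives 2 nM in this assay.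

Compound 4 `O=C(NCCCNc1nc(Nc2cccc(F)c2)ncc1C1CC1)c1cccs1` has not yet been measured: 3-fluorophenyl in place of 4-fluorobenzyl on a nitrogen on an aromatic ring. For the measured compounds named here, the one measured step that bears on this change, an at least 12-fold higher number from compound 1 to compound 2 (1.08 log units; beyond the scatter), ran the other way, from a fluorophenyl to a fluorobenzyl, and was large. Reversing that direction, the number for compound 4 is expected to fall well below that of compound 2, although the shift from 2-fluorophenyl to 3-fluorophenyl has no measured counterpart here. The estimated step of an at least 10-fold lower number from compound 2 to compound 4 (1.00 log units; beyond the scatter) is therefore a large drop. Compound 4 is expected to give about 1000 nM, within the range 250 nM to 4000 nM.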

Compound 4, half-maximal inhibitory concentration: 110 nM
Estimate against measurement, compound 4: 9.1-fold (0.96 log units) above; the whole stated range lies above it.
By their numbers in this assay, from the lowest: compound 3; then compound 4; then compound 1. At a limit, above all of these: compound 2.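

With 3-fluorophenyl in place of 2-fluorophenyl, the ring on the nitrogen stays the same and only the fluorine changes place, yet this gives a 7.5-fold lower number from compound 1 to compound 4 (0.87 log units; beyond the scatter), so the place of the fluorine matters at this position in this assay. The larger step, an at least 90-fold lower number from compound 2 to compound 4 (1.95 log units; beyond the scatter), combines that kind of change with the loss of the benzyl carbon, so it cannot be divided between the two. Compound 2 gives a limit of the assay and not a number, which makes that step a lower bound: the limit of > 10000 nM in this assay, at which 1 of the 4 values shown sits.

From the compounds shown here alone, how a 4-fluorophenyl or a phenyl without fluorine would compare with the 3-fluorophenyl remains open. So does whether a 3-fluorobenzyl would recover any of the strength lost by compound 2.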